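Swapping the amide group on compound 2 for diethylamino

A few compounds are considered here, and "the series" means these few. Any claim that something is new, unique, unknown or untested is made for them only; others in the source may bear on it.

Compound 1 `CCOC(=O)C1=C(N)Oc2ccc(-c3ccccc3)cc2C1CC(=O)N1CCCCC1`: 58500 nM
Compound 2 `CCOC(=O)C1=C(N)Oc2ccc(-c3ccccc3)cc2C1CC(=O)N1CCNCC1`: 53700 nM

In a functional assay on Jurkat cells (Homo sapiens) for cytotoxicity, with a stated time of 48 h (on this read-out higher numbers stand for weaker inhibition and lower numbers for stronger inhibition), compound 2 gives 53700 nM, level with compound 1 within the usual scatter. Compound 3 `CCOC(=O)C1=C(N)Oc2ccc(-c3ccccc3)cc2C1CC(=O)N(CC)CC` alters one group of compound 2: diethylamino in place of piperazin-1-yl on a carbonyl carbon. Put simply, diethylamino stands in place of piperazin-1-yl on a carbonyl carbon. For the measured compounds named here, only one measured step bears on this, a swap at the same place: a 1.1-fold lower number from compound 1 to compound 2 (0.04 log units; within the scatter). That step stays within the scatter, so no step beyond the scatter is expected here. Neither measured compound has an open chain at this place, so the range stays wide. The expected step is a 1.0-fold lower number from compound 2 to compound 3 (0.01 log units; within the scatter). For compound 3 the estimated value is 52000 nM, with an expected range of 25000 nM to 100000 nM.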

Compound 3, half-maximal inhibitory concentration: 49600 nM
Beside the measured number, compound 3's estimate is 1.0-fold (0.02 log units) above it; low and high end bracket the measured number.
By their numbers in this assay, from the lowest: compounds 3, 2 and 1 (each within the scatter of the next).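

This position now carries an open chain as well as rings, yet in this assay neither swap moves the number beyond the scatter (a 1.1-fold lower number from compound 2 to compound 3 (0.03 log units; within the scatter)) (a 1.2-fold lower number from compound 1 to compound 3 (0.07 log units; within the scatter)). Losing the ring and the hydrogen-bond donor of piperazin-1-yl therefore leaves no readable mark on this read-out among these three compounds. Nothing measured here offers an explanation for this flat result. As far as these compounds go, whether any group on this carbonyl carbon can shift the number remains open. A carboxylic acid, or an amine at the end of a longer chain, would test this.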